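Replacing a substituted pyrrolidine with azepane on the piperidine ring

A few compounds are considered here, and "the series" means these few. Any claim that something is new, unique, unknown or untested is made for them only; others in the source may bear on it.

Compound 1: `Cc1nn([C@H](C)c2ccc(Cl)cc2Cl)c2nc(N3CC[C@H](N4CCC[C@H]4CCS(C)(=O)=O)[C@H](C)C3)cnc12` gives 104 nM in a functional assay on cells for antagonist activity at C-C chemokine receptor type 4 (Homo sapiens), read by fluorescence and calcium flux, with stated times of 2.5 s and 45 s; a higher number here means a weaker inhibitor, a lower number a stronger inhibitor.
Compound 2: `CC1CN(c2cnc3c(C#N)nn(C(C)c4ccc(Cl)cc4Cl)c3n2)CCC1N1CCCCC1` gives 251 nM in this assay.

Among the two measured compounds, compound 1 holds the lower number, and its gap to compound 2 lies beyond the usual scatter. Among the compounds with values here, compound 2 differs from compound 1 in more than one place, so the two values show only that the compound bearing a plain saturated amine on the six-membered ring sits at the weaker end.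

Compound 3, `Cc1nn([C@H](C)c2ccc(Cl)cc2Cl)c2nc(N3CC[C@H](N4CCCCCC4)[C@H](C)C3)cnc12`, has not yet been measured. It is derived from compound 1 by one change: azepan-1-yl in place of 2-(2-(methylsulfonyl)ethyl)pyrrolidin-1-yl on a saturated ring carbon. Within the data shown here, no single-point step of this kind exists among the measured compounds, but compound 2, with its plain cyclic amine, gives 251 nM, a weaker reading than compound 1.

Compound 3 is therefore expected to land somewhat above compound 1, a step of a 2.4-fold higher number from compound 1 to compound 3 (0.38 log units; beyond the scatter) in this assay, with an estimated value of 250 nM and a likely range from 80 nM to 800 nM.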

Compound 3, half-maximal inhibitory concentration: 23 nM
The estimate for compound 3 lay 11-fold (1.04 log units) above the measured number, and the stated range ends above it.
By their numbers in this assay, from the lowest: compound 3; then compound 1; then compound 2.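

At the saturated ring carbon next to the ring atom that bears a methyl group, putting azepan-1-yl in place of 2-(2-(methylsulfonyl)ethyl)pyrrolidin-1-yl gives a 4.5-fold lower number from compound 1 to compound 3 (0.66 log units; beyond the scatter) in this assay on the shared core. In this pair, the position therefore keeps its activity without the methylsulfonyl-bearing chain, and an unsubstituted seven-membered ring with fewer heavy atoms gives the lower number. Nothing available explains why this step goes in this direction.

The single change swaps ring size and removes the side chain together, so the compounds shown leave open which of the two accounts for the step. An unsubstituted pyrrolidin-1-yl, or an azepane carrying the same methylsulfonylethyl chain, would be needed to separate the two.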